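Ring methylation on a trimethoxynaphthalene diester series

The compounds below may be only part of what the source reports. "The series", "measured", "known", "first", "only" and "open" are said of these compounds alone.

Measured compounds:
- compound 1, `CCC(=O)Oc1c(OC)c(OC)c(OC(=O)CC)c2ccccc12`, 3.44
- compound 2, `CCC(=O)Oc1c(OC)c(OC)c(OC(=O)CC)c2cc(C)ccc12`, 3.9
- compound 3, `COc1c(OC)c(OC(=O)C(C)(C)C)c2cc(C)ccc2c1OC(=O)C(C)(C)C`, 6.1

In a physicochemical assay for lipophilicity (a higher number here means a more lipophilic compound, a lower number a more polar compound), compound 1 gives 3.44, the lowest partition coefficient of the three. Compound 2 carries the change methyl in place of hydrogen on an aromatic carbon on the core of compound 1, and in this assay compound 2 gives 3.9. For the measured compounds named here, this step, a number 0.46 log units higher from compound 1 to compound 2 (beyond the scatter), is the only measured single-point change in the set. Compound 3 gives 6.1 in this assay, the highest of the three; the difference between the core of compound 3 and the core of compound 1 is not broken down here.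

Compound 4, `COc1c(OC)c(OC(=O)C(C)(C)C)c2cc(C)c(C)cc2c1OC(=O)C(C)(C)C`, is not yet measured. Its difference from compound 3 is methyl in place of hydrogen on an aromatic carbon. Around the place, the entering methyl in compound 4 is ortho to a methyl group (1 heavy atom), which was not the case for the change from compound 1 to compound 2; the two changes are therefore the same kind of change, not the same.

Going by the values given here, for compound 4 a step of about a number 0.45 log units higher from compound 3 to compound 4 (beyond the scatter) in this assay is expected, of the same size as a number 0.46 log units higher from compound 1 to compound 2 (beyond the scatter), because that step a number 0.46 log units higher from compound 1 to compound 2 (beyond the scatter) is the one measured instance of this kind of change. Compound 4 is thus estimated at 6.55 in this assay, within 6.2 to 6.9.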

Compound 4, partition coefficient: 6.5
Estimate against measurement, compound 4: 0.05 log units above, and the stated range covers the measured number.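

In this assay, methyl in place of hydrogen on an aromatic carbon gives a number 0.40 log units higher from compound 3 to compound 4 (beyond the scatter), which has the same direction and the same modest size class as a number 0.46 log units higher from compound 1 to compound 2 (beyond the scatter). The change therefore carried from the core of compound 1 to the core of compound 3, even though the entering methyl in compound 4 is ortho to a methyl group, but these are only two instances and they set no rule for other cores or other places on the ring, and the influence of that neighbouring methyl cannot be separated from the influence of the core. Nothing available explains why the two steps resemble each other.

For the compounds shown here, the only group entering on the aromatic carbon in these compounds is methyl, so it remains open whether an amine, a carboxylic acid or a longer chain such as propyl at that place would shift this assay in a comparably regular way from one core to the other. Also open, on these data alone, is whether a second methyl, ortho to a methyl group, would give a similar step on the core of compound 2, where it would sit in the same surroundings apart from the ester groups.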